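Series notes: removing the distal ring from compound 2

A few compounds are considered here, and "the series" means these few. Any claim that something is new, unique, unknown or untested is made for them only; others in the source may bear on it.

Compound 1 `O=C(CC1c2ccccc2N=C(SCCCCCN2CCCC2)N1c1ccc(-c2ccccc2)cc1)NCc1ccc(F)cc1`: 15000 nM
Compound 2 `O=C(CC1c2ccccc2N=C(SCCCCCN2CCCC2)N1c1ccc(-c2ccc(F)cc2)cc1)NCc1ccc(F)cc1`: 12600 nM
Compound 3 `O=C(CC1c2ccccc2N=C(SCCCCCN2CCCC2)N1c1ccc(-c2ccc(F)cc2)cc1)NCc1ccccc1`: 2180 nM

In an assay on cells for inhibition of Voltage-dependent T-type calcium channel subunit alpha-1G (Homo sapiens), read by patch clamp (a higher number here means a weaker inhibitor, a lower number a stronger inhibitor), compound 2 sits second highest of the three numbers, close to compound 1 and well above compound 3, with a 5.8-fold lower number from compound 2 to compound 3 (0.76 log units; beyond the scatter) on the benzylamide side of the core. Compound 4 `O=C(CC1c2ccccc2N=C(SCCCCCN2CCCC2)N1c1ccccc1)NCc1ccc(F)cc1` differs from compound 2 by hydrogen in place of 4-fluorophenyl on an aromatic carbon. Within the data shown here, only one measured step touches that ring, a 1.2-fold lower number from compound 1 to compound 2 (0.08 log units; within the scatter), and it exchanges a single atom rather than removing the whole ring, so no measured step bears directly on this change. The expectation is therefore weakly held: compound 4 is expected to give 16000 nM, range 5000 nM to 50000 nM. The step of a 1.3-fold higher number from compound 2 to compound 4 (0.10 log units; within the scatter) is expected to be small, not clearly beyond the scatter.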

Compound 4, half-maximal inhibitory concentration: 13500 nM
For compound 4 the middle estimate is 1.2-fold (0.07 log units) above the measured one, and the stated range covers the measured number.
By their numbers in this assay, from the lowest: compound 3; then compounds 2, 4 and 1 (each within the scatter of the next).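

In this assay, losing the whole terminal ring gives no step beyond the scatter, whether that ring is 4-fluorophenyl (a 1.1-fold higher number from compound 2 to compound 4 (0.03 log units; within the scatter)) or phenyl (a 1.1-fold lower number from compound 1 to compound 4 (0.05 log units; within the scatter)). With the fluorinated benzylamide in place, this position therefore accepts hydrogen as well as either ring, which the earlier single-atom exchange could not show. Nothing available explains this insensitivity.

On these data alone, it remains open whether hydrogen is equally accepted with the unfluorinated benzylamide of compound 3. Also open, as far as these compounds go, is whether an amine, a carboxylic acid or a pyridine ring at this position would shift the number.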